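The source may report more compounds than this note shows. Statements on the series, on what has been measured and on what is new or still open speak of the compounds shown alone.

Measured so far:
- compound 1, `COc1ccccc1/C=c1\c(=O)[nH]/c(=C/c2cccc(Cl)c2Cl)c(=O)n1C`: 100 nM
- compound 2, `C=CCn1c(=O)/c(=C\c2ccc(Cl)c(Cl)c2)[nH]c(=O)/c1=C\c1ccccc1`: "not active" (no number reported)
- compound 3, `C=CCn1c(=O)/c(=C\c2cc(F)ccc2C)[nH]c(=O)/c1=C\c1ccccc1OC`: 1000 nM

Working notes on the series. In a functional assay on U-937 cells (Homo sapiens) for cytotoxicity, read by CCK-8 assay, with a stated time of 72 h (a lower number here means a stronger inhibitor, a higher number a weaker inhibitor), compound 1 gives 100 nM. In this assay compound 2 is reported as "not active" (no number reported), with no number attached. In this assay compound 3 gives 1000 nM, the highest of the two numbers in hand; the nearest is compound 1, whose lower number lies beyond the scatter of the assay.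

The next compound, compound 4, `C=CCn1c(=O)/c(=C\c2cccc(Cl)c2)[nH]c(=O)/c1=C\c1ccccc1OC`, differs from compound 3 in one place: 3-chlorophenyl in place of 5-fluoro-2-methylphenyl on a double-bonded chain carbon bound to an aromatic carbon. Within the data shown here, no pairwise step is available to calibrate this change; compound 1 and compound 2 differ from compound 3 in more than one place, so only their raw values can be compared.

Taking the shared core as given, the change is expected to move the number somewhat downward, since compound 1, the only chlorophenyl bearer with a number, gives 100 nM. The step is estimated as a 2.0-fold lower number from compound 3 to compound 4 (0.30 log units; within the scatter), a modest gain that may well sit within the scatter. For compound 4 the expected value in this assay is 500 nM, with a range from 150 nM to 2000 nM.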

Compound 4, half-maximal inhibitory concentration: 1200 nM
The estimate for compound 4 lay 2.4-fold (0.38 log units) below the measured number, within the range that was stated.
By their numbers in this assay, from the lowest: compound 1; then compounds 3 and 4 (each within the scatter of the next).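

In this assay the step is a 1.2-fold higher number from compound 3 to compound 4 (0.08 log units; within the scatter) for 3-chlorophenyl in place of 5-fluoro-2-methylphenyl on a double-bonded chain carbon bound to an aromatic carbon. Among these compounds, this is the first single-place comparison, and on this core the two substituted phenyl groups cannot be told apart, so the exchange shows no measurable effect at this position. Nothing in hand accounts for this outcome.

From the compounds shown here alone, whether a phenyl ring carrying an amine or a carboxylic acid, or a longer chain in place of the phenyl ring, would move the number at this place remains open. Also open, going by these compounds, is whether the same exchange would give a similar result on the core of compound 1, since a single step on one core cannot settle that.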